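The source may report more compounds than this note shows. Statements on the series, on what has been measured and on what is new or still open speak of the compounds shown alone.

Measured in an assay on HEK293 cells for displacement of a labelled ligand from 5-hydroxytryptamine receptor 7 (Rattus norvegicus); on this read-out lower numbers stand for stronger inhibition and higher numbers for weaker inhibition:
compound 1 `O=C(CCCCCN1CCN(c2noc3ccccc23)CC1)NC1CCCc2ccccc21` gives 125 nM
compound 2 `O=C(CCCCCN1CCN(c2nc3ccccc3o2)CC1)NC1CCCc2ccccc21` gives 820 nM

Within the data shown here, compound 2 stands at the highest of the two numbers in this assay; its only neighbour is compound 1, and the gap between them is the single measured step, a 6.6-fold higher number from compound 1 to compound 2 (0.82 log units; beyond the scatter). That step exchanges one fused bicyclic ring for another on the amine nitrogen in a ring and says nothing about substitution on the six-membered carbon ring of the fused system.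

Compound 3 is `COc1ccc2oc(N3CCN(CCCCCC(=O)NC4CCCc5ccccc54)CC3)nc2c1`. Relative to compound 2 the change is methoxy in place of hydrogen on an aromatic carbon. Among the measured compounds shown here, no measured step bears on this change: nothing in the two measured compounds varies a substituent on the benzoxazole ring, and the one step on record touches a different part of the molecule. The expectation therefore rests on the change being small relative to the whole structure. For compound 3 the step is expected to be a 1.1-fold lower number from compound 2 to compound 3 (0.04 log units; within the scatter), a number not clearly beyond the scatter in either direction. The estimate for compound 3 in this assay is 750 nM, with a range from 250 nM to 2300 nM.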

Compound 3, inhibition constant: 704 nM
For compound 3 the middle estimate is 1.1-fold (0.03 log units) above the measured one; the measured number falls inside the stated range.
By their numbers in this assay, from the lowest: compound 1; then compounds 3 and 2 (each within the scatter of the next).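

In this assay, methoxy in place of hydrogen on an aromatic carbon of the six-membered ring gives a 1.2-fold lower number from compound 2 to compound 3 (0.07 log units; within the scatter), so this carbon carries methoxy with no difference that can be told from the scatter. Compound 1 remains apart from this pair, with a 5.6-fold higher number from compound 1 to compound 3 (0.75 log units; beyond the scatter), so the 5-methoxy-1,3-benzoxazol-2-yl group on the amine nitrogen in a ring does not reach the number of compound 1. Nothing at hand accounts for either step.

From the compounds shown here alone, it remains open whether this carbon would show the same flat result with other groups, such as chlorine, hydroxy or trifluoromethyl, and whether methoxy on the other aromatic carbons of that ring would read the same. Also open, going by these compounds, is whether methoxy on the six-membered aromatic ring of the group in compound 1 would leave the number there equally unmoved, since the present pair speaks only for the group in compound 2.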